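The source may report more compounds than this note shows. Statements on the series, on what has been measured and on what is new or still open speak of the compounds shown alone.

Compound 1, `COCCOc1nc(N)nc2c1ncn2/C=C1/CC1(CO)CO` — > 20000 nM
Compound 2, `CCCNc1nc(N)nc2c1ncn2/C=C1/CC1(CO)CO` — > 20000 nM

In an ADME assay on CCRF-HSB-2 cells (Homo sapiens) for cytotoxicity, with a stated time of 7 days (on this read-out higher numbers stand for lower toxicity in this test and lower numbers for higher toxicity in this test), compound 1 gives > 20000 nM, which is a limit of the assay rather than a number. Compound 2 gives > 20000 nM in this assay, again only a limit. The step that the two limits leave unreadable from compound 1 to compound 2 is therefore of unreadable size. Within the data shown here, compound 1 stands at the limit alone, and the one other value shown sits there too: the limit of > 20000 nM in this assay, at which 2 of the 2 values shown sit.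

Compound 3, `CCCCNc1nc(N)nc2c1ncn2/C=C1/CC1(CO)CO`, differs from compound 1 in one place: butylamino in place of 2-methoxyethoxy on an aromatic carbon. Among the measured compounds shown here, the single measured step, from compound 1 to compound 2, exchanges the same leaving group for a close relative of the entering one, yet its two limits leave its size unreadable. No readable step bears on the change, so no movement beyond the scatter is expected in this assay. Compound 3 is estimated at 30000 nM, within 15000 nM to 80000 nM. The expected step that the limit leaves unreadable from compound 1 to compound 3 is what this estimate means.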

Compound 3, half-maximal cytotoxic concentration: > 20000 nM
Compound 3 was reported as a limit; the forecaster's own chance of this, stated with the estimate: 80%; the middle value does not contradict the limit.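

In this assay compound 3 gives > 20000 nM, which is a limit and not a number. The steps joining compound 1, compound 2 and compound 3 therefore cannot be read: the limit of > 20000 nM in this assay, at which 3 of the 3 values shown sit. From the compounds shown here alone, what stays open is whether exchanging these groups changes toxicity in this test at all.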